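Acetyl for ethoxy on the compound 2 core

The source may hold more compounds than are shown below. What is called first, only, known or untested is meant among the compounds shown, and "the series" means these compounds.

Going by the values given here, compound 2 `CCOc1ccccc1OC(C)C1=NCCN1` gives 3160 nM in a functional assay on CHO cells for agonist activity at Alpha-2B adrenergic receptor (Homo sapiens) (a higher number here means that more compound is needed for the effect, a lower number that less compound is needed), the lowest of the two numbers so far; compound 1 `CC(Oc1ccccc1S(C)(=O)=O)C1=NCCN1` gives 10000 nM. Among the compounds with values here, the single measured step, a 3.2-fold lower number from compound 1 to compound 2 (0.50 log units; beyond the scatter), put ethoxy in place of methylsulfonyl. Compound 3 `CC(=O)c1ccccc1OC(C)C1=NCCN1` carries acetyl in place of ethoxy on an aromatic carbon, so the ethoxy that accompanied the lower number is lost again, though not to methylsulfonyl. Within the data shown here, no step in hand involves acetyl, so only a modest rise in this assay is expected, smaller than the reverse of the step from methylsulfonyl to ethoxy: a 1.9-fold higher number from compound 2 to compound 3 (0.28 log units; within the scatter). Compound 3 is therefore estimated at 6000 nM, with a range from 2000 nM to 20000 nM.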

Compound 3, half-maximal effective concentration: 295 nM
The estimate for compound 3 lay 20-fold (1.31 log units) above the measured number; the whole stated range lies above it.
By their numbers in this assay, from the lowest: compound 3; then compound 2; then compound 1.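

In this assay this aromatic carbon, ortho to a group of 8 heavy atoms, tolerates more than the earlier pair indicated: acetyl in place of ethoxy gives an 11-fold lower number from compound 2 to compound 3 (1.03 log units; beyond the scatter) and acetyl in place of methylsulfonyl gives a 34-fold lower number from compound 1 to compound 3 (1.53 log units; beyond the scatter) as the lowest number of the series. Ethoxy and acetyl match in heavy atoms and hydrogen-bond acceptors, while acetyl adds a double bond outside aromatic rings. No measurement available here accounts for the drop.

On these data alone, whether the carbonyl alone carries this result remains open. An aldehyde, a methyl ester, an amide or a longer propanoyl chain on the same carbon would test that.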